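Pentylamino Replaces an Amide on the Sulfonamide Core

This account rests on a few compounds, and the source may have more. Where it says the series, first, only, none or still open, it means among the compounds named here.

Compound 1 `Cc1noc(NS(=O)(=O)c2cccc3c(NC(=O)C(C)C)cccc23)c1C` was tested in an assay on VSM-A10 cells for antagonist activity at Endothelin-1 receptor (Rattus norvegicus) (a higher number here means a weaker inhibitor, a lower number a stronger inhibitor), and gave 880 nM. Two other compounds sharing its sulfonamide and isoxazole portion were also read in this assay. Compound 3 `Cc1noc(NS(=O)(=O)c2ccc(NCC(=O)O)cc2)c1C` gave 12000 nM in this assay, a much higher number than compound 1 and a gap well beyond the scatter. Compound 2 `Cc1noc(N(CC(=O)O)S(=O)(=O)c2ccc(N)cc2)c1C` gave only a limit in this assay, > 32000 nM, so no number is known for it. Compound 1 therefore carries the lowest number among the values that were read as numbers.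

Compound 4 `CCCCCNc1cccc2c(S(=O)(=O)Nc3onc(C)c3C)cccc12` has not yet been measured in this assay. It differs from compound 1 in a single place: pentyl in place of isopropylcarbonyl on a nitrogen on an aromatic ring. Among the compounds with values here, no measured pair covers an exchange of this kind, so the expectation rests on compound 1 alone. Compound 4 is estimated to give 1500 nM in this assay, with a range from 300 nM to 8000 nM. The step of a 1.7-fold higher number from compound 1 to compound 4 (0.23 log units; within the scatter) is expected to be modest, toward a somewhat higher number, and not clearly beyond the scatter.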

Compound 4, half-maximal inhibitory concentration: 80 nM
For compound 4 the middle estimate is 19-fold (1.27 log units) above the measured one; measured number below the stated range.
By their numbers in this assay, from the lowest: compound 4; then compound 1; then compound 3. At a limit, above all of these: compound 2.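

In this assay, the nitrogen on the aromatic ring proves to be a place where the group matters: pentyl in place of isopropylcarbonyl gives an 11-fold lower number from compound 1 to compound 4 (1.04 log units; beyond the scatter). The earlier compounds shown here offered no exchange at this place, and this step shows that the carbonyl of compound 1 is not required for a low number, as the pentyl that enters has no carbonyl and no hydrogen-bond acceptor. Nothing among the data shown accounts for the size of this step.

On these data alone, whether a shorter or longer chain on this nitrogen, or a pentyl chain ending in an amine or a carboxylic acid, would hold the number of compound 4 remains open. Also open, as far as these compounds go, is how much of the step belongs to the loss of the carbonyl and how much to the pentyl chain itself.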